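The source may report more compounds than this note shows. Statements on the series, on what has been measured and on what is new or still open speak of the compounds shown alone.

compound 1 `C=CCOc1cc(/C=C/C(=O)c2ccc(OC)c3c2OC(C)(C)C=C3)ccc1OC`: > 10000 nM (a limit)
compound 2 `CCC(=O)Oc1cc(/C=C/C(=O)c2ccc(OC)c3c2OC(C)(C)C=C3)ccc1OC`: 160 nM
compound 3 `COc1ccc(/C=C/C(=O)c2ccc(OC)c3c2OC(C)(C)C=C3)cc1OS(=O)(=O)Cc1ccccc1`: > 10000 nM (a limit)

In a functional assay on K562 cells (Homo sapiens) for cytotoxicity, read by MTT assay (on this read-out higher numbers stand for weaker inhibition and lower numbers for stronger inhibition), compound 3 gives only a limit, > 10000 nM. It stands at the limit of > 10000 nM in this assay, at which 2 of the 3 values shown sit, and only compound 2 gives a number. Compound 4 `COc1ccc(/C=C/C(=O)c2ccc(OC)c3c2OC(C)(C)C=C3)cc1OS(=O)(=O)c1ccc(C)cc1` carries 4-methylphenyl in place of benzyl on a sulfonyl sulfur. Among the compounds with values here, no measured step makes this change. All of them change the group on an oxygen on an aromatic ring. The nearest is large: an at least 62-fold higher number from compound 2 to compound 3 (1.79 log units; beyond the scatter). Another is equally large: an at least 62-fold lower number from compound 1 to compound 2 (1.79 log units; beyond the scatter). The third, a step that the two limits leave unreadable from compound 1 to compound 3, cannot be sized. Compound 4 keeps the sulfonyl link of compound 3, so no step beyond the scatter is expected in this assay, and the expected step reads a number no higher from compound 3 to compound 4 (the limit leaves the size open). The estimate for compound 4 is 10000 nM, with a range from 1500 nM to 30000 nM.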

Compound 4, half-maximal inhibitory concentration: 7850 nM
Compound 4: the middle estimate sits 1.3-fold (0.11 log units) above what was measured, and the stated range covers the measured number.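

In this assay, within the data shown here, compound 4 is the first compound with a sulfonyl link here to give a number rather than a limit, so that link can now be sized against propanoyl on this oxygen: a 49-fold higher number from compound 2 to compound 4 (1.69 log units; beyond the scatter). Placing 4-methylphenyl on the sulfonyl sulfur gives an at least 1.2-fold lower number from compound 3 to compound 4 (0.10 log units; that floor lies within the scatter), and the comparison with allyl gives an at least 1.2-fold lower number from compound 1 to compound 4 (0.10 log units; that floor lies within the scatter), so neither step shows a change beyond the scatter. Both of these comparisons rest on a limit: the limit of > 10000 nM in this assay, at which 2 of the 4 values shown sit.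

Still open, from the compounds shown here alone, is whether the gain seen with propanoyl extends to other groups joined through a carbonyl, such as acetyl or benzoyl, or to a carbamate on this oxygen.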